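Moving the Nitrile on a Cyanophenyl Amide

The source may report more compounds than this note shows. Statements on the series, on what has been measured and on what is new or still open speak of the compounds shown alone.

In an ADME assay on MT4 cells (Homo sapiens) for cytotoxicity, read by MTT assay, with a stated time of 5 days (a lower number here means that less compound is tolerated, a higher number that more compound is tolerated), compound 1 (`COc1cc2nc([S+]([O-])CC(=O)Nc3ccc(Cl)cc3)nc(Nc3c(Cl)cc(/C=C/C#N)cc3Cl)c2cc1OC`) gives 14400 nM as a measured number. Compound 2 (`COc1cc2nc([S+]([O-])CC(=O)Nc3ccccc3C(F)(F)F)nc(Nc3c(Cl)cc(/C=C/C#N)cc3Cl)c2cc1OC`) reads > 192000 nM as a limit of the assay. Compound 3 (`COc1cc2nc([S+]([O-])CC(=O)Nc3cccc(C#N)c3)nc(Nc3c(Cl)cc(/C=C/C#N)cc3Cl)c2cc1OC`) reads >= 70300 nM and is likewise only a limit. Both changes raised the number clearly: an at least 13-fold higher number from compound 1 to compound 2 (1.12 log units; beyond the scatter) and an at least 4.8-fold higher number from compound 1 to compound 3 (0.68 log units; beyond the scatter) are the steps. Compound 4 (`COc1cc2nc([S+]([O-])CC(=O)Nc3ccc(C#N)cc3)nc(Nc3c(Cl)cc(/C=C/C#N)cc3Cl)c2cc1OC`) puts 4-cyanophenyl in place of 3-cyanophenyl on the amide-type nitrogen (4-cyanophenyl in place of 3-cyanophenyl on an amide-type nitrogen). Its group keeps the nitrile of compound 3 but resembles the 4-chlorophenyl of compound 1 at 14400 nM in name, so a modest fall is expected in this assay rather than no change. The estimated step runs an at least 1.7-fold lower number from compound 3 to compound 4 (0.24 log units; that floor lies within the scatter) as a rough expectation. For compound 4 the expected value is 40000 nM within an estimated range of 11000 nM to 150000 nM here.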

Compound 4, half-maximal cytotoxic concentration: >= 188000 nM
Compound 4 ended at the assay's limit; the forecaster's own chance of this, stated with the estimate: 40%; middle value at least 4.7-fold (0.67 log units) away from the limit.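

With the group on the amide-type nitrogen otherwise unchanged, cyano in place of chloro on the aromatic carbon gives an at least 13-fold higher number from compound 1 to compound 4 (1.11 log units; beyond the scatter) in this assay. The low number of compound 1 therefore does not carry over to every group in that position, and compound 4 is only a limit. The steps to compound 4 from compound 2 and from compound 3 cannot be read, as all three values are limits.

On these data alone, whether moving the nitrile changes this number at all remains open. Also open, as far as these compounds go, is whether a carboxylic acid or an amine in place of the nitrile would behave like chloro or like cyano.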